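Removing the Cyano Group from Compound 2

The compounds below may be only part of what the source reports. "The series", "measured", "known", "first", "only" and "open" are said of these compounds alone.

Compound 2 `CC(C)=CCOc1cc(Nc2nccs2)ccc1C#N` sits among the higher numbers in a functional assay on MT2 cells (Homo sapiens) for cytotoxicity; a higher number here means that more compound is tolerated, a lower number that less compound is tolerated: compound 2 gives 500 nM, level at the digits shown with compound 1 `CC(C)=CCOc1cc(Nc2nccc(N)n2)ccc1Cl`, for which compound 1 gives 500 nM, and together these are the highest of the three measured values. Compound 3 `CC(C)=CCOc1cc(Nc2ccccn2)ccc1C#N` lies a little lower, as compound 3 gives 290 nM, and the step of a 1.7-fold lower number from compound 2 to compound 3 (0.24 log units; within the scatter) stays within the scatter.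

Compound 4 `CC(C)=CCOc1cccc(Nc2nccs2)c1` differs from compound 2 in one place: hydrogen in place of cyano on an aromatic carbon. Among the compounds with values here, no measured step removes a cyano group on an aromatic carbon, so nothing among the measured compounds speaks directly to this change. Within the data shown here, the only measured step, from compound 2 to compound 3, is within the scatter and concerns a different part of the molecule. Compound 4 is therefore expected to stay close to compound 2, with a step of about no change at the digits printed from compound 2 to compound 4 (within the scatter) that is not expected to exceed the scatter. The estimate for compound 4 is 500 nM, between 200 nM and 1200 nM.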

Compound 4, half-maximal cytotoxic concentration: 23000 nM
For compound 4 the middle estimate is 46-fold (1.66 log units) below the measured one, outside the stated range (above it).
By their numbers in this assay, from the lowest: compounds 3, 1 and 2 (each within the scatter of the next); then compound 4.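

In this assay this aromatic carbon, ortho to a (3-methylbut-2-en-1-yl)oxy group and para to a (1,3-thiazol-2-yl)amino group, proves to be a sensitive place: hydrogen in place of cyano gives a 46-fold higher number from compound 2 to compound 4 (1.66 log units; beyond the scatter), so far less compound is tolerated with the cyano group present than without it. Within the data shown here, the only earlier step, a 1.7-fold lower number from compound 2 to compound 3 (0.24 log units; within the scatter), changed the ring on the nitrogen and gave no sign of a change of this size. Among these compounds, no information at hand explains why this single replacement moves the number so far.

The compounds shown do not tell whether another group on this carbon, such as fluorine, methoxy or an amine, would behave like cyano or like hydrogen. They also leave open whether the same replacement would move the number as far with the pyridin-2-yl group of compound 3.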